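Benzyl for methylcarbamoyl on the amine: a stability estimate

This account rests on a few compounds, and the source may have more. Where it says the series, first, only, none or still open, it means among the compounds named here.

The three measured compounds share one core and differ only in the group on the sulfonyl sulfur or the carbonyl carbon. In an ADME assay on microsomes from liver (Rattus norvegicus) for metabolic stability, with a stated time of 10 min (on this read-out lower numbers stand for a less stable compound and higher numbers for a more stable compound), compound 1 `Cc1ccccc1S(=O)(=O)NC(=O)c1ccc(Nc2nc(NC3(c4ccc(Cl)cc4)CC3)nc(OCC(F)(F)F)n2)cc1` gives 100%. Compound 2 `CNC(=O)NCCS(=O)(=O)NC(=O)c1ccc(Nc2nc(NC3(c4ccc(Cl)cc4)CC3)nc(OCC(F)(F)F)n2)cc1` gives 100%, and compound 3 `COC(=O)NCCS(=O)(=O)NC(=O)c1ccc(Nc2nc(NC3(c4ccc(Cl)cc4)CC3)nc(OCC(F)(F)F)n2)cc1` gives 100%. Compound 2 therefore stands level with both neighbours: the step of no change at the digits printed from compound 1 to compound 2 (within the scatter) and the step of no change at the digits printed from compound 2 to compound 3 (within the scatter) both lie within the scatter, as does no change at the digits printed from compound 1 to compound 3 (within the scatter).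

Compound 4 `O=C(NS(=O)(=O)CCNCc1ccccc1)c1ccc(Nc2nc(NC3(c4ccc(Cl)cc4)CC3)nc(OCC(F)(F)F)n2)cc1` is now to be measured. It differs from compound 2 in one place: benzyl in place of methylcarbamoyl on an amine nitrogen. None of the three measured steps touches this change; they exchange a 2-methylphenyl for a substituted ethyl on the sulfonyl sulfur, or a methylamino for a methoxy on the carbonyl carbon, and each left this assay unmoved at the digits printed. The entry of a benzyl on the amine nitrogen is thus untested, and the expectation rests on the level of compound 2 alone.

For compound 4 a value of 88% is expected, with a range from 55% to 100%, which would mean an estimated step of a number 12 percentage points lower from compound 2 to compound 4 (beyond the scatter).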

Compound 4, percent of the compound remaining: 100%
For compound 4 the middle estimate is 12 percentage points below the measured one; the range from low to high includes it.
By their numbers in this assay, from the lowest: compounds 1, 2, 3 and 4 (each within the scatter of the next).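

Putting a benzyl on the amine nitrogen in place of the methylcarbamoyl, and so a six-membered aromatic ring of carbon only in place of a group with a hydrogen-bond donor and acceptor, gives no change at the digits printed from compound 2 to compound 4 (within the scatter) in this assay and thus shows that this exchange on the amine nitrogen leaves the read-out level. The same holds for benzyl in place of methoxycarbonyl on that nitrogen, with no change at the digits printed from compound 3 to compound 4 (within the scatter) on this read-out, and for 2-(benzylamino)ethyl in place of 2-methylphenyl on the sulfonyl sulfur, with no change at the digits printed from compound 1 to compound 4 (within the scatter) here too. Nothing measured on these compounds accounts for this level result, so no cause can be offered for it.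

Still open, going by these compounds, is whether the level result in this assay would hold for 2-aminoethyl on the sulfonyl sulfur, with no benzyl or carbonyl group on the amine nitrogen, or for a propyl chain in place of the ethyl chain. A carboxylic acid on the benzyl ring is just as open, and with all four compounds level, the compounds shown set no limit on what this position will take.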